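A Halogen Swap Close to the Assay Limit

A few compounds are considered here, and "the series" means these few. Any claim that something is new, unique, unknown or untested is made for them only; others in the source may bear on it.

Compound 1 (`O=C1O/C(=C\Cn2cnc3c(F)nc(F)c(Cl)c32)C(OCc2ccccc2)=C1OCc1ccccc1`): > 100000 nM (a limit)
Compound 2 (`O=C1O/C(=C\Cn2cnc3cncc(Br)c32)C(OCc2ccccc2)=C1OCc1ccccc1`): 15000 nM (a number)
Compound 3 (`O=C1O/C(=C\Cn2cnc3ccnc(Cl)c32)C(OCc2ccccc2)=C1OCc1ccccc1`): > 100000 nM (a limit)

In a functional assay on HeLa cells (Homo sapiens) for antiproliferative activity, read by MTT assay, with a stated time of 72 h (a higher number here means a weaker inhibitor, a lower number a stronger inhibitor), compound 3 gives > 100000 nM as its result, which is a limit and not a number. The unmeasured compound 4 (`O=C1O/C(=C\Cn2cnc3c(Cl)c(F)nc(F)c32)C(OCc2ccccc2)=C1OCc1ccccc1`) differs from it in one place, where the change is a group of 12 heavy atoms (6 carbon, 3 nitrogen, 2 fluorine, 1 chlorine; one five-membered aromatic ring with 2 hetero atoms, one six-membered aromatic ring with 1 hetero atom) in place of a group of 10 heavy atoms (6 carbon, 3 nitrogen, 1 chlorine; one five-membered aromatic ring with 2 hetero atoms, one six-membered aromatic ring with 1 hetero atom), on a saturated chain carbon bound to a double-bonded chain carbon and the rest stays the same. The measured step that swaps groups with these same counts is a step that the two limits leave unreadable from compound 1 to compound 3 and gives no size to work from. Only compound 2 gives a number, 15000 nM in this assay here. Its two steps, an at least 6.6-fold lower number from compound 1 to compound 2 (0.82 log units; beyond the scatter) and an at least 6.6-fold higher number from compound 2 to compound 3 (0.82 log units; beyond the scatter) in turn, show that changing this group can move the result by a modest amount. A small move towards a lower number is therefore expected, though compound 4 may well stay at the limit. The expected change is an at least 1.6-fold lower number from compound 3 to compound 4 (0.22 log units; that floor lies within the scatter) as a rough guide. For compound 4 the estimated value is 60000 nM with an expected range of 12000 nM to 150000 nM in this estimate.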

Compound 4, half-maximal inhibitory concentration: > 100000 nM
Compound 4: only a limit was reported; the forecaster's own chance of this, stated with the estimate: 55%; middle value at least 1.6-fold (0.22 log units) from the limit.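

Going by these compounds alone, the group entering here holds the same atom counts as the one in compound 1, arranged differently, and in this assay compound 4 gives > 100000 nM, a limit and not a number. Rearranging those halogens therefore brings no readable gain, and the bromine-bearing group stays apart, with an at least 6.6-fold higher number from compound 2 to compound 4 (0.82 log units; beyond the scatter). The steps among compound 1, compound 3 and compound 4 cannot be read, because they rest on limits alone: the limit of > 100000 nM in this assay, at which 3 of the 4 values shown sit.

Whether the bromine itself accounts for the measurable result of compound 2 stays open, with no compound shown differing from it by that atom alone. Also open, going by these compounds, is how an iodine or a methyl group in place of that bromine, on the shared core, would read in this assay.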